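Carbamoyl to 4-Methoxyphenyl: Expected Half-Life of Compound 4

This account rests on a few compounds, and the source may have more. Where it says the series, first, only, none or still open, it means among the compounds named here.

Measured so far:
Compound 1, `NS(=O)(=O)c1cc(-c2nnc(CCl)o2)c(Cl)cc1SCc1ccccc1`, gives 0.235 h in an ADME assay on microsomes from liver (Homo sapiens) for metabolic stability, read by LC-MS, using NADPH, tested at 5 uM; a higher number here means that the compound lasts longer, a lower number that the compound disappears faster.
Compound 2, `CN1CCN(Cc2nnc(-c3cc(S(N)(=O)=O)c(SCc4ccccc4)cc3Cl)o2)CC1`, gives 0.308 h in this assay.
Compound 3, `NC(=O)c1cn(Cc2nnc(-c3cc(S(N)(=O)=O)c(SCc4ccccc4)cc3Cl)o2)nn1`, gives 0.435 h in this assay.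

Compound 3 has the highest of the three numbers, but its edge over compound 2 and over compound 1 is within the scatter, so the three stand together rather than in an order. Compound 4, `COc1ccc(-c2cn(Cc3nnc(-c4cc(S(N)(=O)=O)c(SCc5ccccc5)cc4Cl)o3)nn2)cc1`, differs from compound 3 by 4-methoxyphenyl in place of carbamoyl on an aromatic carbon. Going by the values given here, none of the measured steps touches this position: a 1.9-fold higher number from compound 1 to compound 3 (0.27 log units; within the scatter) and a 1.4-fold higher number from compound 2 to compound 3 (0.15 log units; within the scatter) both changed the group on the saturated chain carbon, and a 1.3-fold higher number from compound 1 to compound 2 (0.12 log units; within the scatter) did the same, all within the scatter. The present change is larger in what enters, yet nothing measured here points to a direction. Compound 4 is therefore expected to stay close to compound 3, with a 1.2-fold lower number from compound 3 to compound 4 (0.09 log units; within the scatter) as the estimated step. The estimated value for compound 4 is 0.35 h, expected to fall between 0.15 h and 0.8 h.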

Compound 4, half-life: 0.215 h
For compound 4 the middle estimate is 1.6-fold (0.21 log units) above the measured one; low and high end bracket the measured number.
By their numbers in this assay, from the lowest: compounds 4, 1, 2 and 3 (each within the scatter of the next, the first and the last beyond it).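

In this assay, going by these compounds alone, the aromatic carbon of the five-membered ring with 3 nitrogen proves sensitive to what it carries, with a 2.0-fold lower number from compound 3 to compound 4 (0.31 log units; beyond the scatter) as the only step in this set beyond the scatter, though a modest one. The change swaps carbamoyl for the larger 4-methoxyphenyl, which brings a six-membered aromatic ring of carbon only and removes a hydrogen-bond donor, so several counted features shift together in this single step. Nothing measured here gives a reason for the shorter half-life.

The compounds shown leave open whether the lower number follows from losing carbamoyl or from gaining 4-methoxyphenyl, and whether an unsubstituted phenyl or a methyl on this carbon would read nearer compound 3 or compound 4. Equally open, on these data alone, is how a carboxylic acid or an amine here would read in this assay.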